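A few compounds are considered here, and "the series" means these few. Any claim that something is new, unique, unknown or untested is made for them only; others in the source may bear on it.

Three compounds share one core and differ only in the aryl group on the ring amine of the sulfonamide-linked piperazine. Compound 1 `CCCn1c(=O)[nH]c2nc(-c3ccc(S(=O)(=O)N4CCN(c5ccc(F)cc5)CC4)cc3)[nH]c2c1=O` carries a 4-fluorophenyl there; in an assay on CHO cells for displacement of a labelled ligand from adenosine receptor A1 (Homo sapiens), read by scintillation counting, with a stated time of 90 min, in the presence of a further agent that is not named here (on this read-out higher numbers stand for weaker inhibition and lower numbers for stronger inhibition), compound 1 gives > 1000 nM, which is a limit of the assay and not a number. Compound 2 `CCCn1c(=O)[nH]c2nc(-c3ccc(S(=O)(=O)N4CCN(c5ccccc5C)CC4)cc3)[nH]c2c1=O` carries a 2-methylphenyl and in this assay compound 2 gives 419 nM, so that an at least 2.3-fold lower number from compound 1 to compound 2 (0.37 log units; beyond the scatter). Compound 3 `CCCn1c(=O)[nH]c2nc(-c3ccc(S(=O)(=O)N4CCN(c5cccc(Cl)c5)CC4)cc3)[nH]c2c1=O` carries a 3-chlorophenyl. In this assay compound 3 gives > 1000 nM, again a limit and not a number. Compound 3 therefore stands at the limit of > 1000 nM in this assay, at which 2 of the 3 values shown sit, and the step of an at least 2.3-fold higher number from compound 2 to compound 3 (0.37 log units; beyond the scatter) is the only readable one that reaches it, since a step that the two limits leave unreadable from compound 1 to compound 3.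

Compound 4 `CCCn1c(=O)[nH]c2nc(-c3ccc(S(=O)(=O)N4CCN(c5ccccc5F)CC4)cc3)[nH]c2c1=O` is the next change: 2-fluorophenyl in place of 3-chlorophenyl on an amine nitrogen in a ring. For the measured compounds named here, the one compound with a group on the same side of the phenyl, compound 2, gave a measurable number 419 nM, so compound 4 is expected to give a measurable number as well, with an estimated step of an at least 1.6-fold lower number from compound 3 to compound 4 (0.22 log units; that floor lies within the scatter). The estimate for compound 4 is 600 nM, within a range from 250 nM to 1500 nM.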

Compound 4, inhibition constant: > 1000 nM
Compound 4 was reported as a limit (the forecaster's own chance of this, stated with the estimate: 35%); at least 1.6-fold (0.22 log units) between middle value and limit.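

Fluoro in place of methyl on an aromatic carbon gives an at least 2.3-fold higher number from compound 2 to compound 4 (0.37 log units; beyond the scatter), so the 2 in the group's name is not enough for a measurable value in this assay: with these two compounds, the outcome depends on which group sits on the phenyl. Compound 2 is now the only compound shown with a measured number, and the steps from compound 1 and compound 3 to compound 4 cannot be read, since both ends of each are limits. The result for compound 4 is itself a limit and not a number, and it joins a shared ceiling: the limit of > 1000 nM in this assay, at which 3 of the 4 values shown sit.

From the compounds shown here alone, how far compounds 1, 3 and 4 lie beyond that limit stays unknown. Also open, going by these compounds, is whether 2-ethylphenyl, 2-chlorophenyl or 2-methoxyphenyl would behave like the 2-methylphenyl of compound 2 or the 2-fluorophenyl of compound 4.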